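This account rests on a few compounds, and the source may have more. Where it says the series, first, only, none or still open, it means among the compounds named here.

Compound 1 `Fc1ccc(C2CC(c3ccc(Cl)s3)=NN2c2nc(-c3ccc(Cl)cc3)cs2)cc1` gives in an ADME assay on NIH3T3 cells (Mus musculus) for cytotoxicity, read by XTT assay, with a stated time of 24 h (a lower number here means a stronger inhibitor, a higher number a weaker inhibitor), a value of > 500 ug/mL, which is a limit of the assay rather than a number.
Compound 2 `Fc1ccc(C2CC(c3ccc(Cl)s3)=NN2c2nc(-c3ccc(Br)cc3)cs2)cc1` gives > 500 ug/mL, again a limit.
Compound 3 `Fc1ccc(C2CC(c3ccc(Cl)s3)=NN2c2nc(-c3ccccc3)cs2)cc1` gives > 500 ug/mL, also a limit.

Compound 3 thus stands at the limit of > 500 ug/mL in this assay, at which 3 of the 3 values shown sit, together with the other two. Compound 4 `COc1ccc(-c2csc(N3N=C(c4ccc(Cl)s4)CC3c3ccc(F)cc3)n2)cc1` differs from compound 3 by methoxy in place of hydrogen on an aromatic carbon. For the measured compounds named here, the steps that bear on it, a step that the two limits leave unreadable from compound 1 to compound 3 and a step that the two limits leave unreadable from compound 2 to compound 3, as well as a step that the two limits leave unreadable from compound 1 to compound 2, give no readable size, since all three values sit at the same limit. Nothing in these numbers points to a step beyond the scatter in either direction, so the step from compound 3 to compound 4 is expected to read as a number no higher from compound 3 to compound 4 (the limit leaves the size open). Compound 4 is therefore estimated to give 500 ug/mL, in a range from 150 ug/mL to 1500 ug/mL, most likely again reported only as a limit.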

Compound 4, half-maximal inhibitory concentration: 103 ug/mL
Beside the measured number, compound 4's estimate is 4.9-fold (0.69 log units) above it; measured number below the stated range.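

The earlier compounds shown here left this position unread, with none of their steps readable: the limit of > 500 ug/mL in this assay, at which 3 of the 4 values shown sit. Methoxy on this aromatic carbon gives the first real number in this assay, with an at least 4.8-fold lower number from compound 3 to compound 4 (0.68 log units; beyond the scatter) for methoxy in place of hydrogen, an at least 4.8-fold lower number from compound 2 to compound 4 (0.68 log units; beyond the scatter) for methoxy in place of bromo, and an at least 4.8-fold lower number from compound 1 to compound 4 (0.68 log units; beyond the scatter) for methoxy in place of chloro. The read-out therefore does respond to what sits on this ring, though each step gives only a minimum size.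

As far as these compounds go, whether the oxygen of methoxy is what matters stays open. A hydroxyl, an ethoxy or an amine on the same carbon would bear on that.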